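From 4-hydroxyphenyl to 4-chlorobenzyl on a shared core

A few compounds are considered here, and "the series" means these few. Any claim that something is new, unique, unknown or untested is made for them only; others in the source may bear on it.

In an ADME assay on RAW264.7 cells (Mus musculus) for cytotoxicity, read by MTT assay (on this read-out higher numbers stand for weaker inhibition and lower numbers for stronger inhibition), compound 1 `COc1cc(/C=C/c2nc(Nc3ccc(O)cc3)c3sccc3n2)cc(OC)c1OC` gives > 50000 nM, which is a limit of the test and not a number. Compound 2 `COc1cc(/C=C/c2nc(NCc3ccccc3)c3sccc3n2)cc(OC)c1OC` gives > 50000 nM, and this too is a limit. Together they leave one piece of evidence: the limit of > 50000 nM in this assay, at which 2 of the 2 values shown sit.

Compound 3 `COc1cc(/C=C/c2nc(NCc3ccc(Cl)cc3)c3sccc3n2)cc(OC)c1OC` has not yet been measured. It differs from compound 1 in a single place: 4-chlorobenzyl in place of 4-hydroxyphenyl on a nitrogen on an aromatic ring. For the measured compounds named here, the one measured step at this place is a step that the two limits leave unreadable from compound 1 to compound 2, with benzyl entering in place of 4-hydroxyphenyl. That step offers no size to carry over, so no change beyond the scatter is expected in this assay, in either direction. The expected step is a number no higher from compound 1 to compound 3 (the limit leaves the size open). Compound 3 is estimated at 50000 nM, with an expected range of 20000 nM to 100000 nM, and it may well be reported only as a limit.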

Compound 3, half-maximal inhibitory concentration: > 50000 nM
Compound 3: a limit, no number; the forecaster's own chance of this, stated with the estimate: 75%; the middle value sits exactly at the limit.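

No step can be read among compound 1, compound 2 and compound 3, since each gives only a limit of the test and not a number: the limit of > 50000 nM in this assay, at which 3 of the 3 values shown sit.

On these data alone, whether 4-hydroxyphenyl, benzyl or 4-chlorobenzyl on the shared core makes any difference in this assay stays open, as does the concentration at which any of the three would inhibit.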